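A 4-(diethylamino)butyl chain on the shared core

The source may report more compounds than this note shows. Statements on the series, on what has been measured and on what is new or still open speak of the compounds shown alone.

Measured in a functional assay on HL60/MX2 cells (Homo sapiens) for antiproliferative activity, read by MTT assay, with a stated time of 48 h; on this read-out higher numbers stand for weaker inhibition and lower numbers for stronger inhibition:
- compound 1 `CN1CCN(CCn2c(N)c(-c3nc4ccccc4[nH]3)c3nc(C#N)c(C#N)nc32)CC1`: 6490 nM
- compound 2 `CN1CCN(CCCn2c(N)c(-c3nc4ccccc4[nH]3)c3nc(C#N)c(C#N)nc32)CC1`: 3320 nM

Compound 2, at 3320 nM, sits within the usual scatter of compound 1, so the two cannot be told apart on these numbers. Compound 3 `CCN(CC)CCCCn1c(N)c(-c2nc3ccccc3[nH]2)c2nc(C#N)c(C#N)nc21` has not been measured yet. Its structure differs from that of compound 2 as follows: (diethylamino)methyl in place of 4-methylpiperazin-1-yl on a saturated chain carbon, three bonds along the chain from an aromatic nitrogen. Read one bond further out, 3-(4-methylpiperazin-1-yl)propyl gives way to 4-(diethylamino)butyl. Among the measured compounds shown here, one measured step bears on this, a 2.0-fold lower number from compound 1 to compound 2 (0.29 log units; within the scatter), since it also alters the chain. For the measured compounds named here, no measured compound carries a diethylamino group, so that part of the change remains untested. The expected change is a 1.1-fold lower number from compound 2 to compound 3 (0.04 log units; within the scatter), which means no step beyond the scatter is expected, though with wide uncertainty. For compound 3 the estimated value in this assay is 3000 nM, with an expected range from 1000 nM to 9000 nM.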

Compound 3, half-maximal inhibitory concentration: 1550 nM
Compound 3: middle estimate off by 1.9-fold (0.29 log units), on the high side; low and high end bracket the measured number.
By their numbers in this assay, from the lowest: compound 3; then compounds 2 and 1 (each within the scatter of the next).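

In this assay, 4-(diethylamino)butyl in place of 3-(4-methylpiperazin-1-yl)propyl gives a 2.1-fold lower number from compound 2 to compound 3 (0.33 log units; beyond the scatter), so this position responds to the change by more than the scatter, which the step between compound 1 and compound 2 did not show. Measured against the 2-(4-methylpiperazin-1-yl)ethyl chain, the same 4-(diethylamino)butyl chain gives a 4.2-fold lower number from compound 1 to compound 3 (0.62 log units; beyond the scatter), a modest gain in inhibition across the three compounds. Nothing measured here explains this gain.

Compound 3 differs from the other two in both its amine and its chain length, so the two changes cannot be separated. From the compounds shown here alone, a 4-(4-methylpiperazin-1-yl)butyl chain or a 3-(diethylamino)propyl chain would help to separate them, and other end groups, such as a morpholine or a dimethylamino group, remain open.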